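A few compounds are considered here, and "the series" means these few. Any claim that something is new, unique, unknown or untested is made for them only; others in the source may bear on it.

Working notes on the series. Compound 1, `Cc1ccc(-c2c(S(=O)(=O)c3ccccc3)cnc3cc(C)nn23)cc1`, in a functional assay on the whole organism for inhibition, with Mus musculus as the target, with a stated time of 5 h, at a dose of 50 mg/kg by the oral route (on this read-out lower numbers stand for less inhibition and higher numbers for more inhibition at the one dose given (going by the name of the read-out)), gives 8.1%. Compound 2, `Cc1ccc(-c2c(S(=O)(=O)c3ccccc3)cnc3ncnn23)cc1`, gives 2.4% in this assay, and compound 3, `Cc1cc2ncc(S(=O)(=O)c3ccccc3)c(-c3ccc(Br)cc3)n2n1`, gives 0%. Compound 1 has the highest of the three numbers, yet each of the other two lies within the scatter of it, so no ranking among the three can be drawn from these figures. Among the compounds with values here, the single one-place step measured, a number 8.1 percentage points lower from compound 1 to compound 3 (within the scatter), is within the scatter.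

Compound 4, `Cc1ccc(-c2c(S(=O)(=O)c3ccccc3)cnc3cc(-c4ccccc4)nn23)cc1`, differs from compound 1 in one place: phenyl in place of methyl on an aromatic carbon. Within the data shown here, no measured step covers a phenyl for methyl exchange on this ring; the bromo for methyl step sits on a different aromatic carbon and was itself within the scatter, and compounds 1 and 2 differ elsewhere in the core with numbers that also sit within the scatter of each other. Nothing in the series therefore points to a move beyond the scatter in this assay, and the expected step of a number 0.1 percentage points lower from compound 1 to compound 4 (within the scatter) is taken as none beyond the scatter. Compound 4 is estimated at 8%, with an expected range from 0% to 25% in this assay.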

Compound 4, a percentage reported as inhibition, in the whole organism at one dose (the size of the read-out at that dose, not a potency): 28.2%
Estimate against measurement, compound 4: 20.2 percentage points below, and the stated range ends below it.
By their numbers in this assay, from the lowest: compounds 3, 2 and 1 (each within the scatter of the next); then compound 4.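

In this assay, within the data shown here, phenyl in place of methyl on an aromatic carbon of the five-membered aromatic ring with 2 nitrogen gives a number 20.1 percentage points higher from compound 1 to compound 4 (beyond the scatter), the first one-place step to lie beyond the scatter. Among these compounds, this position therefore responds to a change of group, whereas the only earlier one-place step, bromo in place of methyl on a different aromatic carbon, stayed within the scatter; here 1 heavy atom leaves and 6 heavy atoms enter, including one six-membered aromatic ring of carbon only. No supporting measurement bears on why the number rises with this change.

Going by these compounds, it remains open whether the gain belongs to phenyl in particular or would also appear with other groups on this carbon, such as an ethyl or longer alkyl chain, an amine, a carboxylic acid, or a phenyl ring carrying a chloro or methoxy group. Also open, on these data alone, is whether the same exchange would have a comparable effect on the core of compound 2, and whether the step would hold at other doses or times, as the read-out gives the size of the effect at one dose and not a potency.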